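The compounds below may be only part of what the source reports. "The series", "measured", "known", "first", "only" and "open" are said of these compounds alone.

Of the compounds shown here, three built on one shared core have been measured in a functional assay on MCF7 cells (Homo sapiens) for antiproliferative activity, read by MTT assay, with a stated time of 72 h; a higher number here means a weaker inhibitor, a lower number a stronger inhibitor. Compound 1 `COc1ncc(-c2ccc3nc(NC(=O)NCCN4CCCCC4)sc3c2)cc1NS(=O)(=O)c1ccc(F)cc1` gives 450 nM. Compound 2 `COc1ncc(-c2ccc3nc(NC4CC4)sc3c2)cc1NS(=O)(=O)c1ccc(F)cc1` gives 450 nM. Compound 3 `CNC(=O)Nc1nc2ccc(-c3cnc(OC)c(NS(=O)(=O)c4ccc(F)cc4)c3)cc2s1` gives 1190 nM, the highest of the three numbers, and the steps of a 2.6-fold higher number from compound 1 to compound 3 (0.42 log units; beyond the scatter) and a 2.6-fold higher number from compound 2 to compound 3 (0.42 log units; beyond the scatter) both lie beyond the scatter. Compound 4 `COc1ncc(-c2ccc3nc(NC(=O)NCCN4CCN(C)CC4)sc3c2)cc1NS(=O)(=O)c1ccc(F)cc1` differs from compound 3 in one place: (4-methylpiperazin-1-yl)methyl in place of hydrogen on a saturated chain carbon bound to an amide-type nitrogen. The measured step that bears on this is a 2.6-fold higher number from compound 1 to compound 3 (0.42 log units; beyond the scatter), which runs in the opposite direction with a related group on the same carbon, so a return of about that size toward a lower number is expected. In this assay compound 4 is therefore estimated at 450 nM, within a range from 200 nM to 1000 nM. This corresponds to an expected step of a 2.6-fold lower number from compound 3 to compound 4 (0.42 log units; beyond the scatter).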

Compound 4, half-maximal inhibitory concentration: 470 nM
Compound 4: the middle estimate sits 1.0-fold (0.02 log units) below what was measured, and the stated range covers the measured number.
By their numbers in this assay, from the lowest: compounds 1, 2 and 4 (each within the scatter of the next); then compound 3.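

In this assay, (4-methylpiperazin-1-yl)methyl in place of hydrogen on this saturated chain carbon gives a 2.5-fold lower number from compound 3 to compound 4 (0.40 log units; beyond the scatter), while 4-methylpiperazin-1-yl in place of piperidin-1-yl gives a 1.0-fold higher number from compound 1 to compound 4 (0.02 log units; within the scatter), so the same gain over compound 3 now appears with a second ring at this position. Against the cyclopropyl compound, the step is a 1.0-fold higher number from compound 2 to compound 4 (0.02 log units; within the scatter), which places this longer substituent level with cyclopropyl on the nitrogen. No available evidence accounts for these results. Going by these compounds, whether a morpholine ring, an open-chain dimethylamino group or a longer chain would hold this level remains open.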